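Same Boron Core, a Different Group at the Far Ring

The source may hold more compounds than are shown below. What is called first, only, known or untested is meant among the compounds shown, and "the series" means these compounds.

Two compounds share a boron-containing core joined through a short amide linker to an aromatic ring. Compound 1 `COc1ccc(NC(=O)CCc2cccc3c2B(O)OC3)cc1` carries a methoxy group on that ring, and in a functional assay on MDA-MB-231 cells (Homo sapiens) for antiproliferative activity, read by MTT assay, with a stated time of 72 h (on this read-out higher numbers stand for weaker inhibition and lower numbers for stronger inhibition), compound 1 gives 850 nM. Compound 2 `O=C(CCc1cccc2c1B(O)OC2)Nc1cccc(-c2cccc(F)c2)c1` carries a 3-fluorophenyl group instead, and in this assay compound 2 gives 570 nM. The number for compound 2 stands alongside that of compound 1, the gap between them lying within the usual scatter of this kind of measurement, so the two cannot be told apart.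

Compound 3 `CSc1cccc(-c2cccc(NC(=O)CCc3cccc4c3B(O)OC4)c2)c1` has not yet been measured. It differs from compound 2 in one place: methylsulfanyl in place of fluoro on an aromatic carbon. Going by the values given here, no measured pair shows this change, so the expectation rests only on compound 2. A step in this assay of modest size, or none beyond the scatter, is expected. Compound 3 is expected to give about 500 nM, between 200 nM and 1500 nM. This estimate means a step of a 1.1-fold lower number from compound 2 to compound 3 (0.06 log units; within the scatter), not beyond the scatter.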

Compound 3, half-maximal inhibitory concentration: 150 nM
The estimate for compound 3 lay 3.3-fold (0.52 log units) above the measured number; measured number below the stated range.
By their numbers in this assay, from the lowest: compound 3; then compounds 2 and 1 (each within the scatter of the next).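

In this assay, putting methylsulfanyl in place of fluoro on this aromatic carbon gives a 3.8-fold lower number from compound 2 to compound 3 (0.58 log units; beyond the scatter) and so this outer ring position does respond to the group it carries. The gap between the two earlier compounds stayed within the scatter, whereas this exchange of one small group for another moves the number beyond it. No measurement on hand explains why the number falls with this change.

The compounds shown leave open whether the sulfur, the added carbon or the two together account for the step. They also leave open how far an ethylsulfanyl chain, an amine or a carboxylic acid on the same aromatic carbon would move the number, and in which direction.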